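Replacing phenyl with (cyclopropylmethyl)amino: a solubility estimate

A few compounds are considered here, and "the series" means these few. Any claim that something is new, unique, unknown or untested is made for them only; others in the source may bear on it.

Compound 1 (`CS(=O)(=O)c1ccc(-n2nc(C(F)F)c(C#N)c2-c2ccccc2)cc1`) is the starting point of this step, yet it offers no number to start from. In a physicochemical assay for solubility (on this read-out lower numbers stand for lower solubility and higher numbers for higher solubility), compound 1 is recorded as "not determined" (no result reported) and so has no place on the scale. Among the measured compounds shown here, compound 2 (`CC1CCCN(c2c(C#N)c(C(F)(F)F)nn2-c2ccc(S(C)(=O)=O)cn2)C1`) gives 100 ug/mL in this assay and is the only compound here with a measured figure, although it differs from compound 1 in more than one place.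

Compound 3 is drawn as `CS(=O)(=O)c1ccc(-n2nc(C(F)F)c(C#N)c2NCC2CC2)cc1` and has not yet been measured. The structural change is (cyclopropylmethyl)amino in place of phenyl on an aromatic carbon and it puts (cyclopropylmethyl)amino in place of phenyl on an aromatic carbon.

With no measured start, the size of this step in this assay cannot be read from the data. The working expectation is therefore no shift beyond the usual scatter from the one available anchor, where compound 2 gives 100 ug/mL as its reading. One anchor is thin support, so the range is kept wide. The estimated value for compound 3 is 70 ug/mL as a middle figure (expected range 20 ug/mL to 200 ug/mL).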

Compound 3, solubility: > 200 ug/mL
Compound 3 gave a limit, no number; the forecaster's own chance of this, stated with the estimate: 15%; at least 2.8-fold (0.45 log units) between middle value and limit.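

In this assay no step can be read from compound 1 to compound 3: compound 1 has no reported result, and compound 3 gives only a limit of the assay, not a number. The compounds shown leave open how large the change from phenyl to (cyclopropylmethyl)amino is on this read-out, and in which direction it runs.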